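Notes on compound 4: phenyl in place of isobutyl

The source may report more compounds than this note shows. Statements on the series, on what has been measured and on what is new or still open speak of the compounds shown alone.

Measured so far in a functional assay on WiDr cells (Homo sapiens) for antiproliferative activity, read by sulforhodamine B assay, with a stated time of 48 h; on this read-out lower numbers stand for stronger inhibition of growth and higher numbers for weaker inhibition of growth:
Compound 1 `Cc1ccc(S(=O)(=O)N2CC[C@@H](Cl)C[C@@H]2CC(C)C)cc1` gives 22000 nM.
Compound 2 `Cc1ccc(S(=O)(=O)N2CC[C@@H](Cl)C[C@@H]2C2CCCCC2)cc1` gives 15000 nM.
Compound 3 `Cc1ccc(S(=O)(=O)N2CC[C@@H](Br)C[C@@H]2CC(C)C)cc1` gives 14000 nM.

Compound 3 carries the lowest of the three numbers, but its value and that of compound 2 lie within the scatter of each other, and the step of a 1.6-fold lower number from compound 1 to compound 3 (0.20 log units; within the scatter) is likewise within the scatter. On these numbers compound 3 is not set apart from either of the others.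

Compound 4 `Cc1ccc(S(=O)(=O)N2CC[C@@H](Br)C[C@@H]2c2ccccc2)cc1` is compound 3 with the isobutyl group exchanged: phenyl in place of isobutyl on a saturated ring carbon.

Within the data shown here, two measured steps bear on this. Among the measured compounds shown here, the only change at the same saturated ring carbon is a 1.5-fold lower number from compound 1 to compound 2 (0.17 log units; within the scatter), a change of one saturated group for another, within the scatter. The change at the other position, a 1.6-fold lower number from compound 1 to compound 3 (0.20 log units; within the scatter), is also within the scatter. For the measured compounds named here, no compound with an aromatic group at this ring carbon has been measured, so the move to phenyl is not covered directly.

Given that, the step of a 1.2-fold lower number from compound 3 to compound 4 (0.07 log units; within the scatter) is expected to stay within the scatter, with no clear direction. Compound 4 is estimated at 12000 nM, in a range from 5000 nM to 30000 nM.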

Compound 4, concentration for 50% growth inhibition: 36000 nM
The estimate for compound 4 lay 3.0-fold (0.48 log units) below the measured number; measured number outside the range, above it.
By their numbers in this assay, from the lowest: compounds 3, 2, 1 and 4 (each within the scatter of the next, the first and the last beyond it).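

In this assay, among these compounds, the exchange of isobutyl for phenyl gives a 2.6-fold higher number from compound 3 to compound 4 (0.41 log units; beyond the scatter) and is the first step to lie beyond the scatter, though it is modest in size. This shows that the saturated ring carbon next to the ring nitrogen is not indifferent to the group it carries: the earlier change there, a 1.5-fold lower number from compound 1 to compound 2 (0.17 log units; within the scatter) with one saturated group replacing another, stayed within the scatter, while the entry of a six-membered aromatic ring of carbon only moves the number towards weaker inhibition of growth, although the two steps were taken with chloro and with bromo respectively present on the ring. No evidence on the cause of this step is at hand.

It remains open whether phenyl in place of isobutyl gives a step of similar size when chloro rather than bromo is on the ring, as the only pair shown for this change carries bromo. Also open, on these data alone, is how a benzyl group, a pyridyl ring or a chain ending in a carboxylic acid would read at this ring carbon, and so whether the higher number goes with aromatic groups in general or with phenyl alone.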